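The compounds below may be only part of what the source reports. "The series", "measured", "known", "first", "only" and "open" are said of these compounds alone.

Compound 3 `COc1cc(N)c(Cl)cc1NC(=O)C1CCN(CC2CCC2)CC1` stands at the limit of a functional assay on the whole organism for antagonist activity, with Mus musculus as the target; a lower number here means that less compound is needed, a higher number that more compound is needed for the effect: compound 3 gives > 10 mg/kg, which is a limit and not a number. Compound 2 `CCCN1CCC(C(=O)Nc2cc(Cl)c(N)cc2OC)CC1` likewise gives > 10 mg/kg, also a limit (the limit of > 10 mg/kg in this assay, at which 2 of the 3 values shown sit). Only compound 1 `COc1cc(N)c(Cl)cc1NC(=O)C1CCN(Cc2cccc(C)c2)CC1` returns a number, and compound 1 gives 2.4 mg/kg. Compound 4 `CCC(CC)CN1CCC(C(=O)Nc2cc(Cl)c(N)cc2OC)CC1` differs from compound 3 by pentan-3-yl in place of cyclobutyl on a saturated chain carbon bound to an amine nitrogen in a ring. Among the measured compounds shown here, the steps that bear on this change are an at least 4.1-fold higher number from compound 1 to compound 2 (0.61 log units; beyond the scatter) and an at least 4.1-fold higher number from compound 1 to compound 3 (0.61 log units; beyond the scatter), while a step that the two limits leave unreadable from compound 2 to compound 3. Both the ethyl and the cyclobutyl groups thus sit at the limit, and the pentan-3-yl group is expected to behave in the same way, so for compound 4 a step that the limit leaves unreadable from compound 3 to compound 4 is expected. Compound 4 is estimated at 15 mg/kg, between 7 mg/kg and 40 mg/kg, most likely again reported only as a limit.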

Compound 4, dose for half-maximal effect: > 10 mg/kg
Compound 4 gave a limit, no number; the forecaster's own chance of this, stated with the estimate: 70%; the middle value does not contradict the limit.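

In this assay a branched open chain, pentan-3-yl, ends at the same limit as ethyl and cyclobutyl, so no group at this place other than 3-methylphenyl yet returns a number: the limit of > 10 mg/kg in this assay, at which 3 of the 4 values shown sit. Replacing 3-methylphenyl with pentan-3-yl gives an at least 4.1-fold higher number from compound 1 to compound 4 (0.61 log units; beyond the scatter). The steps among the three compounds at the limit cannot be read.

Going by these compounds, whether plain phenyl, 3-chlorophenyl or pyridin-3-yl would also return a number stays open. So does any order among ethyl, cyclobutyl and pentan-3-yl.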